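Bromo on the Core of Compound 3: Expected Inhibition

The compounds below may be only part of what the source reports. "The series", "measured", "known", "first", "only" and "open" are said of these compounds alone.

Measured compounds:
compound 1 `N=c1sc(=S)[nH]c2c1cc(-c1ccc(Cl)cc1)n2-c1ccccc1`: 2%
compound 2 `Cc1ccc(-c2cc3c(=N)sc(=S)[nH]c3n2-c2ccccc2)cc1`: 0%
compound 3 `CCSc1nc2c(cc(-c3ccccc3)n2-c2ccccc2)c(=N)s1`: 0%

In a functional assay on the whole organism for inhibition, with Rattus norvegicus as the target, read by ELISA, with stated times of 30 min and 6 h, at a dose of 30 mg/kg by the oral route (on this read-out higher numbers stand for more inhibition at the one dose given (going by the name of the read-out) and lower numbers for less inhibition), compound 3 gives 0%, level with compound 2 at the digits shown and together with it the lowest of the three numbers; compound 1 lies within the scatter of both. Compound 4 `CCSc1nc2c(cc(-c3ccc(Br)cc3)n2-c2ccccc2)c(=N)s1` differs from compound 3 by bromo in place of hydrogen on an aromatic carbon. Among the compounds with values here, the one measured step, a number 2 percentage points lower from compound 1 to compound 2 (within the scatter), exchanges one substituent for another on an aromatic carbon and stays within the scatter. Within the data shown here, no measured step places a halogen on an unsubstituted ring. Since every measured value sits near zero, no step beyond the scatter is expected here. Compound 4 is therefore expected to give 2%, between 0% and 15%. The expected step is a number 2 percentage points higher from compound 3 to compound 4 (within the scatter).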

Compound 4, a percentage reported as inhibition, in the whole organism at one dose (the size of the read-out at that dose, not a potency): 1%
Beside the measured number, compound 4's estimate is 1 percentage points above it, and the stated range covers the measured number.
By their numbers in this assay, from the lowest: compounds 2, 3, 4 and 1 (each within the scatter of the next).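

In this assay the change from phenyl to 4-bromophenyl gives a number 1 percentage points higher from compound 3 to compound 4 (within the scatter) and so stays within the scatter. The earlier step only put methyl in place of chloro, whereas this one shows that bromo entering on a previously unsubstituted aromatic carbon also produces no step beyond the scatter. Nothing available explains this result. Still open, as far as these compounds go, is whether an amine or a carboxylic acid on this aromatic carbon would give a number beyond the scatter, since all four compounds lie near zero and show no measurable inhibition to build on.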